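Hydroxymethyl in place of the propyl ester group

A few compounds are considered here, and "the series" means these few. Any claim that something is new, unique, unknown or untested is made for them only; others in the source may bear on it.

For the measured compounds named here, compound 2 `CCCOC(=O)c1cc(-c2cccc(OC(=O)NC3CCCCC3)c2)n(-c2ccccc2)n1` gives 27 nM in an assay on isolated protein for inhibition of Fatty-acid amide hydrolase 1 (Homo sapiens), read by fluorescence, with a stated time of 30 min (a lower number here means a stronger inhibitor, a higher number a weaker inhibitor), the lowest of the two numbers so far; compound 1 `NC(=O)c1cc(-c2cccc(OC(=O)NC3CCCCC3)c2)n(-c2ccccc2)n1` gives 169 nM. Going by the values given here, the only measured step, a 6.3-fold lower number from compound 1 to compound 2 (0.80 log units; beyond the scatter), shows the carbonyl-bearing substituent matters at this position. Compound 3 `O=C(NC1CCCCC1)Oc1cccc(-c2cc(CO)nn2-c2ccccc2)c1` carries hydroxymethyl in place of propoxycarbonyl on an aromatic carbon. That step bears on it only indirectly: compound 3 keeps no carbonyl at this carbon, so the gain seen in compound 2 is not expected to hold. A weaker value is expected, with a step of an 11-fold higher number from compound 2 to compound 3 (1.05 log units; beyond the scatter). Compound 3 is estimated at 300 nM, within 80 nM to 1200 nM.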

Compound 3, half-maximal inhibitory concentration: 462 nM
The estimate for compound 3 lay 1.5-fold (0.19 log units) below the measured number; low and high end bracket the measured number.
By their numbers in this assay, from the lowest: compound 2; then compound 1; then compound 3.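

In this assay, hydroxymethyl in place of propoxycarbonyl on this aromatic carbon gives a 17-fold higher number from compound 2 to compound 3 (1.23 log units; beyond the scatter). Hydroxymethyl in place of carbamoyl gives a 2.7-fold higher number from compound 1 to compound 3 (0.44 log units; beyond the scatter), so both carbonyl-bearing groups shown give lower numbers than hydroxymethyl at this position. No measurement here accounts for this order.

Still open, as far as these compounds go, is whether the carbonyl itself or the size of the substituent tracks with these numbers. A carboxylic acid, an aminomethyl group or a longer ester chain at this carbon would help separate the two.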